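The compounds below may be only part of what the source reports. "The series", "measured", "known", "first", "only" and "open" are said of these compounds alone.

In a functional assay on HeLa cells (Homo sapiens) for antiproliferative activity, read by MTT assay, with a stated time of 72 h (a higher number here means a weaker inhibitor, a lower number a stronger inhibitor), compound 1, `O=c1[nH]c(=O)n(CCC(CO)CO)cc1C#Cc1cc(F)cc(F)c1`, gives 31200 nM. Compound 2, `O=c1[nH]c(=O)n(CCC(CO)CO)cc1C#CCc1ccccc1`, gives 63800 nM in this assay. Compound 3, `O=c1[nH]c(=O)n(CCC(CO)CO)cc1C#CC1CC1`, sits at the limit of > 100000 nM in this assay, and this is a limit of the assay rather than a number. Compound 3 thus stands at the weak end of the three numbers shown, with an at least 3.2-fold higher number from compound 1 to compound 3 (0.50 log units; beyond the scatter) and an at least 1.5-fold higher number from compound 2 to compound 3 (0.19 log units; that floor lies within the scatter); the second of these is bounded only by the limit of > 100000 nM in this assay, at which 1 of the 3 values shown sits. Compound 4, `CCCCCCCCC#Cc1cn(CCC(CO)CO)c(=O)[nH]c1=O`, differs from compound 3 by octyl in place of cyclopropyl on a triple-bonded carbon. Going by the values given here, the two measured steps onto the cyclopropyl both moved the number upward, and the reverse change, away from the cyclopropyl toward a larger group, is the only guide here, so a downward move of modest size is expected for compound 4, though with a real chance that the limit is met again. The expected step is an at least 2.0-fold lower number from compound 3 to compound 4 (0.30 log units; that floor lies within the scatter). Compound 4 is accordingly estimated at 50000 nM, between 15000 nM and 160000 nM.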

Compound 4, half-maximal inhibitory concentration: 58900 nM
Compound 4: middle estimate off by 1.2-fold (0.07 log units), on the low side, and the stated range covers the measured number.
By their numbers in this assay, from the lowest: compounds 1, 4 and 2 (each within the scatter of the next, the first and the last beyond it). At a limit, above all of these: compound 3.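

Going by these compounds alone, of the groups on this triple-bonded carbon, octyl is the only one without a ring, and it gives a readable number where cyclopropyl does not, with an at least 1.6-fold lower number from compound 3 to compound 4 (0.22 log units; that floor lies within the scatter). Compound 3 itself remains at a limit of the assay, > 100000 nM, so that step is only a floor: the limit of > 100000 nM in this assay, at which 1 of the 4 values shown sits. Octyl cannot be told apart from benzyl, with a 1.1-fold lower number from compound 2 to compound 4 (0.03 log units; within the scatter), or from 3,5-difluorophenyl, with a 1.9-fold higher number from compound 1 to compound 4 (0.28 log units; within the scatter), so at this place an open chain matches both groups that carry an aromatic ring.

Going by these compounds, it remains open whether the number follows chain length at all, which a butyl group or a longer chain such as dodecyl would test. Also open, on these data alone, is how an amine or a carboxylic acid at the end of the chain would read in this assay.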